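Trifluoromethyl Replaces Cyclohexyl on the Shared Core

This account rests on a few compounds, and the source may have more. Where it says the series, first, only, none or still open, it means among the compounds named here.

Measured compounds:
compound 1 `CCCCOC(=O)NS(=O)(=O)c1ccc(CCC)cc1-c1ccc(Cn2c(C3CCCCC3)nc3ccccc32)cc1`, 130 nM
compound 2 `CCCCOC(=O)NS(=O)(=O)c1ccc(CCC)cc1-c1ccc(Cn2c(CC)nc3ccccc32)cc1`, 11 nM

Compound 1 was tested in an assay on membranes from HEK293 cells for displacement of a labelled ligand from Type-2 angiotensin II receptor (Homo sapiens), read by radioligand binding (on this read-out lower numbers stand for stronger inhibition and higher numbers for weaker inhibition), where compound 1 gave 130 nM, the highest number of the two measured. Within the data shown here, the only measured step from it is the one a 12-fold lower number from compound 1 to compound 2 (1.07 log units; beyond the scatter), in which compound 2 reached 11 nM.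

Compound 3 `CCCCOC(=O)NS(=O)(=O)c1ccc(CCC)cc1-c1ccc(Cn2c(C(F)(F)F)nc3ccccc32)cc1` is the unmeasured compound. It differs from compound 1 as follows: trifluoromethyl in place of cyclohexyl on an aromatic carbon. Among the measured compounds shown here, the sole step that bears on this change is the one a 12-fold lower number from compound 1 to compound 2 (1.07 log units; beyond the scatter), where the cyclohexyl also left and a smaller group entered at the same place. For the measured compounds named here, that step was large and beyond the scatter, so a step of similar direction is expected here, though no measured compound carries a trifluoromethyl at this place and the size is therefore uncertain. Compound 3 is expected to give a lower number than compound 1, a step of a 5.2-fold lower number from compound 1 to compound 3 (0.72 log units; beyond the scatter). Compound 3 is estimated at 25 nM, with a range from 8 nM to 100 nM.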

Compound 3, inhibition constant: 13 nM
Estimate against measurement, compound 3: 1.9-fold (0.28 log units) above, within the range that was stated.
By their numbers in this assay, from the lowest: compounds 2 and 3 (each within the scatter of the next); then compound 1.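

In this assay, the step to trifluoromethyl (a 10-fold lower number from compound 1 to compound 3 (1.00 log units; beyond the scatter)) shows that the lower number seen on leaving cyclohexyl is not confined to ethyl: a second group at this place, with different atoms and also without a ring, gives it too. The comparison with ethyl (a 1.2-fold higher number from compound 2 to compound 3 (0.07 log units; within the scatter)) lies within the scatter, so this read-out does not separate trifluoromethyl from ethyl at this place. The compounds shown come with no further data that could explain these numbers.

Going by these compounds, whether a cyclopropyl ring, a methoxy group or a longer chain such as butyl would stay with ethyl and trifluoromethyl or fall with cyclohexyl remains open. On these data alone, it is also open whether the same changes would give the same result with another group in place of the propyl on the shared core.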